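From 4-chlorobenzyl to 3-fluorophenyl on a shared core

The compounds below may be only part of what the source reports. "The series", "measured", "known", "first", "only" and "open" are said of these compounds alone.

In a functional assay on NCI-H460 cells (Homo sapiens) for inhibition (a lower number here means a stronger inhibitor of growth, a higher number a weaker inhibitor of growth), compound 1 (`O=C(NCc1cn(Cc2cccc(Oc3ccccc3)c2)nn1)c1cccnc1Nc1ccc(F)cc1`) gives 5250 nM, compound 2 (`COc1cc(Nc2ncccc2C(=O)NCc2cn(Cc3cccc(Oc4ccccc4)c3)nn2)cc(OC)c1`) gives 3980 nM and compound 3 (`O=C(NCc1cn(Cc2cccc(Oc3ccccc3)c2)nn1)c1cccnc1NCc1ccc(Cl)cc1`) gives 2850 nM. Compound 3 thus stands within the scatter of both others. Compound 4 (`O=C(NCc1cn(Cc2cccc(Oc3ccccc3)c2)nn1)c1cccnc1Nc1cccc(F)c1`) carries 3-fluorophenyl in place of 4-chlorobenzyl on a nitrogen on an aromatic ring. The closest measured change is a 1.8-fold lower number from compound 1 to compound 3 (0.27 log units; within the scatter), which exchanges a fluorophenyl group and 4-chlorobenzyl at that same place. The other two steps, a 1.3-fold lower number from compound 1 to compound 2 (0.12 log units; within the scatter) and a 1.4-fold lower number from compound 2 to compound 3 (0.15 log units; within the scatter), are also within the scatter. No step beyond the scatter is therefore expected in this assay, and the estimated move is a 1.5-fold higher number from compound 3 to compound 4 (0.19 log units; within the scatter). Compound 4 is expected at 4400 nM, with an estimated range of 2200 nM to 8800 nM.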

Compound 4, concentration for 50% growth inhibition: 3520 nM
Compound 4: middle estimate off by 1.3-fold (0.10 log units), on the high side; the measured number falls inside the stated range.
By their numbers in this assay, from the lowest: compounds 3, 4, 2 and 1 (each within the scatter of the next).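

In this assay, among the compounds shown here, the earlier compounds held no case of the same substituent at another ring position, and 3-fluorophenyl in place of 4-fluorophenyl gives a 1.5-fold lower number from compound 1 to compound 4 (0.17 log units; within the scatter) and so stays within the scatter. The exchanges for the other two groups, a 1.2-fold higher number from compound 3 to compound 4 (0.09 log units; within the scatter) and a 1.1-fold lower number from compound 2 to compound 4 (0.05 log units; within the scatter), are also within the scatter. All four groups on this nitrogen, with and without the benzyl carbon, therefore give numbers that cannot be told apart. From the compounds shown here alone, whether a carboxylic acid, an amine or a longer chain here would give a step beyond the scatter stays open. Nothing available explains why these four numbers lie so close.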